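Dropping a Chloro Group Ortho to a Nitro Group

The source may report more compounds than this note shows. Statements on the series, on what has been measured and on what is new or still open speak of the compounds shown alone.

Compound 1 `CCOC(=O)C1=C(C)NC(=S)NC1c1cn(C(=O)CNc2ccc([N+](=O)[O-])c(Cl)c2)c2ccccc12` is the reference. In a functional assay on MCF7 cells (Homo sapiens) for cytotoxicity, read by MTT assay, with a stated time of 72 h (on this read-out lower numbers stand for stronger inhibition and higher numbers for weaker inhibition), compound 1 gives 50 ug/mL. Compound 2 `CCOC(=O)C1=C(C)NC(=O)NC1c1cn(C(=O)CNc2ccc([N+](=O)[O-])cc2Cl)c2ccccc12` gives 50 ug/mL in this assay, level with compound 1 at the digits shown, so the two cannot be ordered; together they hold the lowest numbers of the three. Compound 3 `CCOC(=O)C1=C(C)NC(=O)NC1c1cn(C(=O)CNc2ccc(Cl)cc2)c2ccccc12` gives 200 ug/mL and is the furthest from compound 1. For the measured compounds named here, the one measured step that differs in a single place is a 4.0-fold higher number from compound 2 to compound 3 (0.60 log units; beyond the scatter).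

Compound 4 `CCOC(=O)C1=C(C)NC(=S)NC1c1cn(C(=O)CNc2ccc([N+](=O)[O-])cc2)c2ccccc12` differs from compound 1 by hydrogen in place of chloro on an aromatic carbon, ortho to a nitro group. Going by the values given here, the step from compound 2 to compound 3 bears on this only loosely, as it removed the nitro group and moved the chloro rather than deleting a chloro alone; it is nonetheless the only guide, and it was modest. The nitro group stays in compound 4, so the expected step in this assay is a small drift toward a higher number or none beyond the scatter, a 1.4-fold higher number from compound 1 to compound 4 (0.15 log units; within the scatter). Compound 4 is therefore estimated at 70 ug/mL, within a range from 30 ug/mL to 200 ug/mL.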

Compound 4, half-maximal inhibitory concentration: > 1000 ug/mL
Compound 4: only a limit was reported; the forecaster's own chance of this, stated with the estimate: 15%; middle value at least 14-fold (1.15 log units) away from the limit.
By their numbers in this assay, from the lowest: compounds 1 and 2 (each within the scatter of the next); then compound 3. At a limit, above all of these: compound 4.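

In this assay, hydrogen in place of chloro, ortho to a nitro group, gives an at least 20-fold higher number from compound 1 to compound 4 (1.30 log units; beyond the scatter). For the compounds shown here, the only earlier step removed the nitro group and moved the chloro together, so it could not isolate the chloro; here the nitro group stays, and this single chlorine atom alone separates a measurable number from no measurable number in the range reported. The value for compound 4 is a limit and not a number, so this step fixes only a minimum size: the limit of > 1000 ug/mL in this assay, at which 1 of the 4 values shown sits.

Whether this position needs chloro itself, or would also hold up with fluoro, bromo, methyl or methoxy in its place, remains open among the compounds shown. From the compounds shown here alone, it is also open whether deleting the chloro from compound 2 would produce a similarly large step.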